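This account rests on a few compounds, and the source may have more. Where it says the series, first, only, none or still open, it means among the compounds named here.

Measured in an ADME assay on RAW264.7 cells (Mus musculus) for cytotoxicity; a lower number here means a stronger inhibitor, a higher number a weaker inhibitor:
- compound 1 `COc1cc2oc(-c3ccc(Br)cc3)cc(=O)c2c(OC)c1OC`: 69900 nM
- compound 2 `COc1cc2oc(-c3ccc([N+](=O)[O-])cc3)cc(=O)c2c(OC)c1OC`: > 100000 nM (a limit of the assay)
- compound 3 `O=c1cc(-c2ccc(Br)cc2)oc2cc(O)c(O)c(O)c12`: 57100 nM

Compound 3, at 57100 nM, lies within the scatter of compound 1, at 69900 nM. The result for compound 2 is only a limit, (the limit of > 100000 nM in this assay, at which 1 of the 3 values shown sits).

The next compound is compound 4 `Nc1ccc(-c2cc(=O)c3c(O)c(O)c(O)cc3o2)cc1`, which carries 4-aminophenyl where compound 3 carries 4-bromophenyl: amino in place of bromo on an aromatic carbon. The change is amino in place of bromo on an aromatic carbon, para to a large group.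

One measured step replaces bromo at this place, an at least 1.4-fold higher number from compound 1 to compound 2 (0.15 log units; that floor lies within the scatter). It brings in nitro rather than amino, on the core of compound 1, and it gives only a floor that stays within the scatter. It therefore offers no firm size or direction, so no clear change is expected in this assay beyond the scatter.

The expected result is a 1.2-fold higher number from compound 3 to compound 4 (0.09 log units; within the scatter). For compound 4 the estimated value is 70000 nM, with an expected range of 30000 nM to 100000 nM.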

Compound 4, half-maximal inhibitory concentration: 94100 nM
For compound 4 the middle estimate is 1.3-fold (0.13 log units) below the measured one; the range from low to high includes it.
By their numbers in this assay, from the lowest: compounds 3, 1 and 4 (each within the scatter of the next). At a limit, above all of these: compound 2.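

In this assay, amino in place of bromo on an aromatic carbon, para to a large group, gives a 1.6-fold higher number from compound 3 to compound 4 (0.22 log units; within the scatter). The earlier replacement of bromo ended in a floor, whereas this step has a number at both ends, and it shows that 4-aminophenyl and 4-bromophenyl lie within the scatter of each other on the core of compound 3. The nitro result stays unresolved, for compound 2 is only a limit of the assay: the limit of > 100000 nM in this assay, at which 1 of the 4 values shown sits.

The compounds shown leave open whether any group at this place, such as a carboxylic acid or a longer alkyl chain, would move the number beyond the scatter. They also leave open whether amino would give a similar result on the core of compound 1, which carries methoxy groups in place of the hydroxyl groups.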